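This account rests on a few compounds, and the source may have more. Where it says the series, first, only, none or still open, it means among the compounds named here.

Among the measured compounds shown here, in an assay on isolated protein (Cricetulus griseus) for binding affinity to Alpha-1B adrenergic receptor (Mesocricetus auratus), read by radioligand binding (a lower number here means a stronger inhibitor, a higher number a weaker inhibitor), the series so far holds three measured compounds and one to come. For the measured compounds named here, compound 1 `Oc1cccc2c1CCCC2c1c[nH]cn1` is the single member with a number: in this assay compound 1 gives 145 nM. Compound 2 `CS(=O)(=O)Nc1ccc(Cl)c2c1CCCC2c1c[nH]cn1` returns only a limit of the assay in this assay, < 10000 nM. Compound 3 `CCS(=O)(=O)Nc1cccc(C2CCNC2)c1` likewise returns only a limit in this assay, < 10000 nM. Where compound 3 stands can thus not be fixed by a number, and no step between measured compounds is known. Going by the values given here, the one note on the numbers is that (the limit of < 10000 nM in this assay, at which 2 of the 3 values shown sit).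

Compound 4 `CCS(=O)(=O)Nc1cccc(-c2c[nH]cn2)c1` is the next candidate. It is formed from compound 3 by one change: 1H-imidazol-4-yl in place of pyrrolidin-3-yl on an aromatic carbon. Compound 1 carries the same aromatic ring on its core and gives a number, while compound 2 carries it too and gives only a limit; a pyrrolidin-3-yl as in compound 3 appears nowhere else in the set. Among the compounds with values here, with no measured step to lean on, no direction can be set with confidence in this assay, and the shift of a step that the limit leaves unreadable from compound 3 to compound 4 is expected only loosely. For compound 4 the expected value in this assay is 1500 nM, with a range from 150 nM to 10000 nM, and a fair chance that the assay again reports only a limit.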

Compound 4, inhibition constant: < 10000 nM
Compound 4: only a limit was reported; the forecaster's own chance of this, stated with the estimate: 40%; the middle value does not contradict the limit.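

Compound 3 and compound 4 both return only a limit in this assay, so no step between them can be read: the limit of < 10000 nM in this assay, at which 3 of the 4 values shown sit.

The compounds shown leave open whether 1H-imidazol-4-yl in place of pyrrolidin-3-yl on an aromatic carbon shifts the value in either direction, with compound 1 at 145 nM still the only number in the series.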